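Series notes: sulfonamide variation on the aryl ring

The source may report more compounds than this note shows. Statements on the series, on what has been measured and on what is new or still open speak of the compounds shown alone.

Compound 1 `CC1CCN(c2nc(C(F)(F)F)ccc2CNC(=O)C(C)c2ccc(NS(=O)(=O)C(C)C)c(F)c2)CC1` gives 8.7 nM in an assay on cells for antagonist activity at transient receptor potential cation channel subfamily V member 1 (Homo sapiens), read by FLIPR and calcium flux, with a stated time of 15 min; a lower number here means a stronger inhibitor, a higher number a weaker inhibitor.
Compound 2 `CC1CCN(c2nc(C(F)(F)F)ccc2CNC(=O)C(C)c2ccc(NS(=O)(=O)N(C)C)c(F)c2)CC1` gives 42 nM in this assay.

Compound 2 stands at the highest number of the pair; its nearest neighbour is compound 1, reached through a 4.8-fold higher number from compound 1 to compound 2 (0.68 log units; beyond the scatter), a change confined to the group on the sulfonyl sulfur.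

Compound 3 `CC1CCN(c2nc(C(F)(F)F)ccc2CNC(=O)C(C)c2ccc(N(C)S(C)(=O)=O)c(F)c2)CC1` has not yet been run in this assay. Its change against compound 2 is methyl(methylsulfonyl)amino in place of (dimethylsulfamoyl)amino on an aromatic carbon. Among the measured compounds shown here, the single measured step, a 4.8-fold higher number from compound 1 to compound 2 (0.68 log units; beyond the scatter), is the only one that touches this region and shows that the sulfonyl substituent alone can move the number by a modest amount. For the measured compounds named here, no measured step removes the hydrogen-bond donor of the sulfonamide nitrogen, so that part of the change has no precedent. The expectation for compound 3 is therefore a step in this assay of a 1.5-fold higher number from compound 2 to compound 3 (0.19 log units; within the scatter), a small shift toward a weaker inhibitor, with wide uncertainty. Compound 3 is estimated at 65 nM, within the range 20 nM to 220 nM.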

Compound 3, inhibition constant: 55.5 nM
Compound 3: middle estimate off by 1.2-fold (0.07 log units), on the high side, and the stated range covers the measured number.
By their numbers in this assay, from the lowest: compound 1; then compounds 2 and 3 (each within the scatter of the next).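

In this assay the replacement of (dimethylsulfamoyl)amino by methyl(methylsulfonyl)amino, on the aromatic carbon ortho to the fluoro group, gives a 1.3-fold higher number from compound 2 to compound 3 (0.12 log units; within the scatter) and so leaves the two compounds within the scatter, even though the entering group has no hydrogen-bond donor where the leaving group has one. Measured against the isopropyl member, the same position gives a 6.4-fold higher number from compound 1 to compound 3 (0.80 log units; beyond the scatter) and so places methyl(methylsulfonyl)amino with (dimethylsulfamoyl)amino, apart from (isopropylsulfonyl)amino, which shows that this position tolerates a group without the donor at a number still close to that of compound 2. No supporting data on the compounds bear on the reason for these numbers.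

The step to compound 3 changes the substituent on the nitrogen and the one on the sulfur together, so the share of each remains unresolved, and an isopropylsulfonyl group paired with a methyl on the nitrogen would be needed to separate them. Also open, going by these compounds, is how this position responds to other sulfonyl substituents, such as cyclopropyl or a longer chain like n-butyl.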